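Trimming the Thioether: Benzoylmethyl Cut Back to Methyl

A few compounds are considered here, and "the series" means these few. Any claim that something is new, unique, unknown or untested is made for them only; others in the source may bear on it.

Compound 2 `Cc1nnc(SCC(=O)c2ccccc2)n1N1C(=O)c2ccccc2C1=O` was tested in a functional assay on A549 cells (Homo sapiens) for cytotoxicity, read by MTT assay, with a stated time of 48 h (on this read-out higher numbers stand for weaker inhibition and lower numbers for stronger inhibition), and its result is only a limit, not a number: compound 2 gives > 200000 nM. Compound 1 `CCOC(=O)CSc1nnc(C)n1N1C(=O)c2ccccc2C1=O` likewise stands at a limit in this assay, where compound 1 gives > 200000 nM. The step that the two limits leave unreadable from compound 1 to compound 2 therefore cannot be read. Compound 3 `CSc1nnc(C)n1N1C(=O)c2ccccc2C1=O` is unmeasured; it differs from compound 2 by hydrogen in place of benzoyl on a saturated chain carbon bound to a sulfur. Both known values sit at the same limit (the limit of > 200000 nM in this assay, at which 2 of the 2 values shown sit), so no readable step bears on this change. Compound 3 is expected to remain at that limit, with an estimate of 300000 nM between 100000 nM and 1000000 nM, an expected step that the limit leaves unreadable from compound 2 to compound 3 within scatter.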

Compound 3, half-maximal inhibitory concentration: > 200000 nM
Compound 3 ended at the assay's limit; the forecaster's own chance of this, stated with the estimate: 90%; the middle value lies beyond the limit too.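

No step among compound 1, compound 2 and compound 3 can be read, because all three stand at one limit of the assay: the limit of > 200000 nM in this assay, at which 3 of the 3 values shown sit.

Going by these compounds, whether any change to the shared core would give a readable value in this assay stays open.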